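The source may report more compounds than this note shows. Statements on the series, on what has been measured and on what is new or still open speak of the compounds shown alone.

Measured compounds:
Compound 1, `CO[C@H]1O[C@H](COc2ccc(C3CCCCC3)cc2)[C@@H](O)[C@H](O)[C@H]1Oc1cccc2c1CCCC2`, gives 37000 nM.
Compound 2, `CO[C@@H]1O[C@H](COc2ccc(-c3ccccc3)cc2)[C@@H](O)[C@H](O)[C@H]1Oc1ccc(OC2CCCCC2)cc1`, gives 36000 nM.
Compound 3, `CO[C@H]1O[C@H](COc2ccc(C3CCCCC3)cc2)[C@@H](O)[C@H](O)[C@H]1Oc1ccc(OC2CCCCC2)cc1`, gives 14000 nM.

All three values come from a functional assay on MDA-MB-231 cells (Homo sapiens) for cytotoxicity, read by MTT assay, with a stated time of 48 h; on this read-out higher numbers stand for an effect only at larger amounts of compound and lower numbers for an effect already at smaller amounts. Compound 1 has the highest number of the three. Its nearest neighbour is compound 2, whose value lies within the usual scatter of compound 1, so the two cannot be told apart. Compound 3 sits furthest away, with a lower number that lies beyond the scatter, so compound 3 acts at smaller amounts than compound 1.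

The next compound, compound 4, `CO[C@H]1O[C@H](COc2ccc(C3CCCCC3)cc2)[C@@H](O)[C@H](O)[C@H]1Oc1ccc2c(c1)CCCC2`, is built from the same atoms as compound 1, joined differently: 1,2,3,4-tetrahydronaphthalen-6-yl in place of 1,2,3,4-tetrahydronaphthalen-5-yl on an oxygen on a saturated carbon. The ring system that leaves and the one that enters have the same size and the same counts of donors and acceptors; only the point at which the ring system is attached to the oxygen moves.

Among the compounds with values here, no pair of measured compounds differs in one place, so there is no measured step to lean on for this change. With only the spread of the three values as a guide, the step from compound 1 to compound 4 is expected to be small, a 1.2-fold lower number from compound 1 to compound 4 (0.09 log units; within the scatter), in no particular direction and likely within the scatter. Compound 4 is therefore estimated at 30000 nM in this assay, with a range from 12000 nM to 80000 nM.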

Compound 4, half-maximal effective concentration: 25000 nM
Compound 4: middle estimate off by 1.2-fold (0.08 log units), on the high side, within the range that was stated.
By their numbers in this assay, from the lowest: compounds 3, 4, 2 and 1 (each within the scatter of the next, the first and the last beyond it).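

Moving the point at which the ring system is attached to the oxygen, with 1,2,3,4-tetrahydronaphthalen-6-yl in place of 1,2,3,4-tetrahydronaphthalen-5-yl, is the first change in this set that can be read on its own, and in this assay it gives a 1.5-fold lower number from compound 1 to compound 4 (0.17 log units; within the scatter). The earlier compounds shown here differed in more than one place, so they could not show how much this single change matters; this pair shows that, on the core of compound 1, the two attachment points cannot be told apart in this test of cell killing. Nothing measured alongside these values bears on this result.

Within the data shown here, the pair covers only one kind of change, a shift of the same ring system, so it remains open whether replacing the 1,2,3,4-tetrahydronaphthalene with a ring carrying an amine or a carboxylic acid would move the number beyond the scatter. On these data alone, it also remains open whether the same shift in attachment point would have as small an effect on a different core.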